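N-substituent swap on the amide nitrogen of the aryloxyacetamide series

The compounds below may be only part of what the source reports. "The series", "measured", "known", "first", "only" and "open" are said of these compounds alone.

Compound 1 `Cc1ccc(OCC(=O)N(Cc2cccs2)c2ncccn2)cc1` gives 3700 nM in an assay on HEK293 cells for agonist activity at transient receptor potential cation channel subfamily M member 8 (Homo sapiens), read by fluorescence and calcium flux, with a stated time of 15 min; a higher number here means that more compound is needed for the effect, a lower number that less compound is needed. For the measured compounds named here, compound 2 `Cc1ccc(OCC(=O)N(O)Cc2cccs2)cc1` gives 8000 nM in this assay and stands at the highest of the two numbers so far; the single step, a 2.2-fold higher number from compound 1 to compound 2 (0.33 log units; beyond the scatter), is modest. Compound 3 `CCCN(Cc1cccs1)C(=O)COc1ccc(C)cc1` is not yet measured; it differs from compound 2 by propyl in place of hydroxy on an amide-type nitrogen. Going by the values given here, only that one step touches the same amide-type nitrogen, and it moved the number by a modest amount, so a step of similar size is expected here, with the direction uncertain and a slight lean towards a lower number. Compound 3 is expected to give 5000 nM in this assay, within 1800 nM to 14000 nM, which amounts to an expected 1.6-fold lower number from compound 2 to compound 3 (0.20 log units; within the scatter).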

Compound 3, half-maximal effective concentration: 40 nM
For compound 3 the middle estimate is 130-fold (2.10 log units) above the measured one, outside the stated range (below it).
By their numbers in this assay, from the lowest: compound 3; then compound 1; then compound 2.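

The amide-type nitrogen proves far more sensitive than the first step showed: in this assay the change to propyl gives a 200-fold lower number from compound 2 to compound 3 (2.30 log units; beyond the scatter) and also a 93-fold lower number from compound 1 to compound 3 (1.97 log units; beyond the scatter) for the swap from pyrimidin-2-yl. Both large steps end at propyl, so on these compounds a plain saturated chain on this nitrogen stands well apart from both hydroxy and pyrimidin-2-yl. Nothing measured on hand accounts for this gain. Open, as far as these compounds go, is whether an ethyl or butyl chain holds the number, and whether a branched isopropyl group or a terminal amine on the chain keeps it.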